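Moving a fluorine around a ring on a sulfonamide piperazine

This account rests on a few compounds, and the source may have more. Where it says the series, first, only, none or still open, it means among the compounds named here.

Two related compounds have been tested in an assay on CHO cells for displacement of a labelled ligand from adenosine receptor A3 (Homo sapiens), read by scintillation counting, with a stated time of 45 min, tested at 1 uM, in the presence of a further agent that is not named here; on this read-out lower numbers stand for less inhibition and higher numbers for more inhibition at the one concentration tested (going by the name of the read-out). Compound 1, with the structure `CCCn1c(=O)[nH]c2nc(-c3ccc(S(=O)(=O)N4CCN(c5cccc(F)c5)CC4)cc3)[nH]c2c1=O`, gives 44% in this assay . Compound 2, with the structure `CCCn1c(=O)c2[nH]c(-c3ccc(S(=O)(=O)N4CCN(c5ccc(Cl)cc5)CC4)cc3)nc2n(C)c1=O`, differs in several places at once and gives 39% in this assay . The gap between these two numbers lies within the usual scatter of such measurements, so the two cannot be told apart, and compound 1 simply sits alongside compound 2 at a similar level of inhibition.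

Compound 3, with the structure `CCCn1c(=O)[nH]c2nc(-c3ccc(S(=O)(=O)N4CCN(c5ccc(F)cc5)CC4)cc3)[nH]c2c1=O`, has not yet been measured. It keeps the whole of compound 1 except for one change: 4-fluorophenyl in place of 3-fluorophenyl on an amine nitrogen in a ring. Among the measured compounds shown here, no measured pair in this set shows what such a change does, so nothing here points to a move in either direction. The expected step from compound 1 to compound 3 in this assay is therefore no change at the digits printed from compound 1 to compound 3 (within the scatter), that is, none beyond the scatter. On that basis compound 3 is expected to give about 44% in this assay , with a plausible range from 25% to 62%.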

Compound 3, a percentage reported as inhibition, at one concentration (the size of the read-out at that concentration, not a potency): 38%
Estimate against measurement, compound 3: 6 percentage points above; low and high end bracket the measured number.
By their numbers in this assay, from the lowest: compounds 3, 2 and 1 (each within the scatter of the next).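

Among the compounds shown here, compound 3 gives the first pair in this set that differs in one place only, and in this assay the swap of 3-fluorophenyl for 4-fluorophenyl on the amine nitrogen of the ring gives a number 6 percentage points lower from compound 1 to compound 3 (within the scatter). The two compounds have the same atoms joined differently, and at this position, on this core, the read-out does not tell the two placements of the fluorine apart. This is a statement about a single pair at a single concentration, and no measurement here offers an explanation for the result.

The compounds shown leave open whether anything at this position can move the number beyond the scatter, for instance a plain phenyl, or a methoxy group, a nitrile or a carboxylic acid in place of the fluorine on the same core. They also leave open whether compound 1 and compound 3 would still look alike in a full concentration series, since a percentage at one concentration is not a potency and could hide a difference between them.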